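A Single Halogen Swap, Repeated on a Second Core

This account rests on a few compounds, and the source may have more. Where it says the series, first, only, none or still open, it means among the compounds named here.

Compound 1, `Cn1cc(C2CC(c3ccc(F)cc3)=NN2C(=O)c2cccnc2)c2cc(Br)ccc21`, gives 480 nM in a functional assay on MCF7 cells (Homo sapiens) for inhibition, read by MTT assay, with a stated time of 48 h; on this read-out higher numbers stand for weaker inhibition of growth and lower numbers for stronger inhibition of growth. Compound 2, `Cn1cc(C2CC(c3ccc(Cl)cc3)=NN2C(=O)c2cccnc2)c2cc(Br)ccc21`, differs only by chloro in place of fluoro on an aromatic carbon, sitting on an aromatic carbon of a six-membered aromatic ring of carbon only, para to a large group, and gives 8100 nM; the step of a 17-fold higher number from compound 1 to compound 2 (1.23 log units; beyond the scatter) is large. Compound 3, `COc1ccc2c(c1)c(C1CC(c3ccc(F)cc3)=NN1C(=O)c1ccc(OC)nc1)cn2C`, carries a different core; how that core differs from the core of compound 1 is not broken down here. In this assay compound 3 gives 480 nM, level with compound 1 at the digits recorded. Going by the values given here, compound 4, `COc1ccc2c(c1)c(C1CC(c3ccc(Cl)cc3)=NN1C(=O)c1ccc(OC)nc1)cn2C`, is not yet measured and differs from compound 3 by chloro in place of fluoro on an aromatic carbon, the same kind of change as the one from compound 1 to compound 2, at a place described in the same words. Among the compounds with values here, it is expected that compound 4 moves in the same direction, with a step of an 8.3-fold higher number from compound 3 to compound 4 (0.92 log units; beyond the scatter), resting on the single precedent a 17-fold higher number from compound 1 to compound 2 (1.23 log units; beyond the scatter) while allowing that one example on another core may not carry over fully. Compound 4 is therefore estimated at 4000 nM, between 1000 nM and 15000 nM.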

Compound 4, concentration for 50% growth inhibition: 3710 nM
For compound 4 the middle estimate is 1.1-fold (0.03 log units) above the measured one; the measured number falls inside the stated range.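

In this assay, putting 4-chlorophenyl in place of 4-fluorophenyl gives a 7.7-fold higher number from compound 3 to compound 4 (0.89 log units; beyond the scatter) on the second core, so growth inhibition weakens in the same direction as on the core of compound 1. The two steps cannot be told apart in size: the same change on two cores in this assay, a 17-fold higher number (1.23 log units; beyond the scatter) from compound 1 to compound 2 and a 7.7-fold higher number (0.89 log units; beyond the scatter) from compound 3 to compound 4, 2.2-fold (0.34 log units) apart, within the scatter of two such steps. This shows that the change carried over between these two cores in direction and, within the scatter, in size, but two matched pairs make no rule for the series and do not show why chloro fares worse than fluoro or whether the step would hold on a third core.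

The compounds shown leave open how other groups at the same place would read, such as 4-bromophenyl, 4-methylphenyl or an amine on the aromatic ring in place of the halogen. They also leave open which of the differences between the two cores, if any, bears on the size of the step.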